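The source may hold more compounds than are shown below. What is called first, only, known or untested is meant among the compounds shown, and "the series" means these compounds.

Measured so far:
compound 1, `COc1cc(-c2cc(C(=O)O)c3ccccc3n2)ccc1OCC(=O)Nc1ccccc1`: 0.7
compound 2, `COc1cc(-c2cc(C(=O)O)c3ccccc3n2)ccc1OCC(=O)NCc1ccco1`: -0.3

In a physicochemical assay for lipophilicity, using the shake flask method, in phosphate buffer, measured as octanol-water partition, at pH 7.4 (a higher number here means a more lipophilic compound, a lower number a more polar compound), compound 1 gives 0.7 and stands highest of the two numbers measured. Among the measured compounds shown here, compound 2 gives -0.3 in this assay, and the only measured step is a number 1.00 log units lower from compound 1 to compound 2 (beyond the scatter), which exchanged the phenyl on the amide-type nitrogen for (furan-2-yl)methyl.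

Compound 3, `COc1cc(-c2cc(C(=O)O)c3ccccc3n2)ccc1OCC(=O)NC1CCCCC1`, has not yet been measured in this assay. It differs from compound 1 in one place: cyclohexyl in place of phenyl on an amide-type nitrogen. The measured step bears on this exchange only loosely, since the group that entered there is not the cyclohexyl that enters here; the amide-type nitrogen and its carbonyl neighbour are the same in both cases. The step measured from compound 1 to compound 2 is not taken as a template for the present one. For compound 3 a modest upward step from compound 1, a number 0.50 log units higher from compound 1 to compound 3 (beyond the scatter), is expected, at the edge of the usual scatter rather than clearly beyond it. Compound 3 is estimated at 1.2 in this assay, within the range 0.5 to 1.9.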

Compound 3, distribution coefficient: 0.8
Compound 3: the middle estimate sits 0.40 log units above what was measured; the range from low to high includes it.
By their numbers in this assay, from the lowest: compound 2; then compounds 1 and 3 (each within the scatter of the next).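

In this assay the exchange on the amide-type nitrogen reads as a number 0.10 log units higher from compound 1 to compound 3 (within the scatter) and so does not separate phenyl from cyclohexyl, although one is a six-membered aromatic ring and the other a six-membered non-aromatic ring, each of 6 carbon atoms. The exchange of (furan-2-yl)methyl reads as a number 1.10 log units higher from compound 2 to compound 3 (beyond the scatter) and is the largest step in the series, so the substituent on this nitrogen can shift the read-out, yet in this pair the loss of ring aromaticity leaves no distinction beyond the scatter, and compound 2 stays apart from both compounds that carry a ring of carbon only. No measurement at hand accounts for either step.

Still open, as far as these compounds go, is whether the distance of compound 2 from the other two belongs to the furan-2-yl ring or to the methyl link that comes with it, a question that benzyl on the same nitrogen would address directly. Also open, from the compounds shown here alone, is how the read-out responds at this position to a longer chain such as 2-phenylethyl, or to an amine or a hydroxyl group carried on the cyclohexyl ring.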